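A Nitro Group in Place of Methoxy, Measured Twice

A few compounds are considered here, and "the series" means these few. Any claim that something is new, unique, unknown or untested is made for them only; others in the source may bear on it.

Of the compounds shown here, three have been tested in a functional assay on HeLa cells (Homo sapiens) for inhibition, read by MTT assay, with a stated time of 72 h; on this read-out higher numbers stand for weaker inhibition and lower numbers for stronger inhibition. Compound 1 `COc1ccc(/C=C/C(=O)c2c(OC)cc(O)c(CC=C(C)C)c2O)cc1` gives a limit of the assay rather than a number, > 50000 nM. Compound 2 `COc1cc(O)c(CC=C(C)C)c(O)c1C(=O)/C=C/c1ccc([N+](=O)[O-])cc1` differs from it by nitro in place of methoxy on an aromatic carbon, and in this assay compound 2 gives 29700 nM, which makes an at least 1.6-fold lower number from compound 1 to compound 2 (0.22 log units; that floor lies within the scatter). Compound 3 `COc1cc(OC)c(C(=O)/C=C/c2ccccc2OC)c(OC)c1` is built on a different core; how that core differs from the core of compound 1 is not broken down here. In this assay compound 3 gives 19600 nM. Compound 4 `COc1cc(OC)c(C(=O)/C=C/c2ccccc2[N+](=O)[O-])c(OC)c1` has not been measured and differs from compound 3 by nitro in place of methoxy on an aromatic carbon. This is the same kind of change as from compound 1 to compound 2, but here the place is ortho to a large group rather than para to it. The earlier step lies within the scatter, so only a small step is expected for compound 4, a 1.3-fold lower number from compound 3 to compound 4 (0.12 log units; within the scatter). Compound 4 is estimated at 15000 nM, between 6000 nM and 40000 nM.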

Compound 4, half-maximal inhibitory concentration: 9000 nM
Compound 4: middle estimate off by 1.7-fold (0.22 log units), on the high side; the measured number falls inside the stated range.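

In this assay, putting nitro in place of methoxy ortho to a large group gives a 2.2-fold lower number from compound 3 to compound 4 (0.34 log units; beyond the scatter), a modest step. Set beside the earlier step, the change lowers the number on both cores, but the two sizes cannot be told apart: the same change on two cores in this assay, an at least 1.6-fold lower number (0.22 log units; that floor lies within the scatter) from compound 1 to compound 2 and a 2.2-fold lower number (0.34 log units; beyond the scatter) from compound 3 to compound 4; the limit leaves it open whether they differ. Compound 1 stands at a limit and not at a number, so these two pairs show a shared direction but neither a shared size nor a rule for other cores: the limit of > 50000 nM in this assay, at which 1 of the 4 values shown sits.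

The compounds shown leave open whether another group in the same place, such as an amine or a carboxylic acid, would give a similar step. They also leave open how the change would behave on a third core.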